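A few compounds are considered here, and "the series" means these few. Any claim that something is new, unique, unknown or untested is made for them only; others in the source may bear on it.

Measured so far in a functional assay on SNB-75 cells (Homo sapiens) for inhibition, read by sulforhodamine B assay, with a stated time of 48 h; on this read-out higher numbers stand for weaker inhibition of growth and lower numbers for stronger inhibition of growth:
compound 1 `COc1cc(-c2nn(-c3cccc(NC(=O)c4ccc(Cl)c(C(F)(F)F)c4)c3)cc2-c2ccncc2)ccc1Cl` gives 29200 nM
compound 2 `COc1cc(-c2nn(-c3cccc(NC(=O)Nc4ccc(Cl)c(C(F)(F)F)c4)c3)cc2-c2ccncc2)ccc1Cl` gives 10300 nM

For the measured compounds named here, compound 2 stands at the lowest number of the two, with compound 1 the only neighbour; the step of a 2.8-fold lower number from compound 1 to compound 2 (0.45 log units; beyond the scatter) is beyond the scatter. Compound 3 `COc1cc(-c2nn(-c3cccc(NC(=O)c4ccccc4)c3)cc2-c2ccncc2)ccc1Cl` is not yet measured; it carries phenyl in place of (4-chloro-3-(trifluoromethyl)phenyl)amino on a carbonyl carbon. Going by the values given here, the one step that bears on it runs the other way: compound 3 returns to a carbonyl bonded directly to an aromatic ring, as in compound 1, while also lacking the chloro and trifluoromethyl groups. A rise in the number is therefore expected, of roughly the size seen in a 2.8-fold lower number from compound 1 to compound 2 (0.45 log units; beyond the scatter) reversed, giving a 3.4-fold higher number from compound 2 to compound 3 (0.53 log units; beyond the scatter). For compound 3 the estimate in this assay is 35000 nM, with a range from 12000 nM to 90000 nM.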

Compound 3, concentration for total growth inhibition: > 100000 nM
Compound 3 gave a limit, no number; the forecaster's own chance of this, stated with the estimate: 15%; middle value at least 2.8-fold (0.45 log units) from the limit.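

In this assay compound 3 gives > 100000 nM, a limit and not a number. Plain phenyl on the carbonyl carbon costs growth inhibition against both substituted partners, with an at least 3.4-fold higher number from compound 1 to compound 3 (0.53 log units; beyond the scatter) and an at least 9.7-fold higher number from compound 2 to compound 3 (0.98 log units; beyond the scatter), so the 4-chloro-3-(trifluoromethyl)phenyl unit, bare or reached through its amino link, is favoured over phenyl at this position. Compound 2 remains the strongest of the three.

Chloro and trifluoromethyl leave together here, so their separate shares stay open. Also open, on these data alone, are a phenyl carrying only chloro or only trifluoromethyl, and a plain phenylamino on the carbonyl carbon.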